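Nitrobenzylamino indazoles: ester in place of cyano

The source may report more compounds than this note shows. Statements on the series, on what has been measured and on what is new or still open speak of the compounds shown alone.

compound 1 `O=[N+]([O-])c1ccccc1CNc1cccc2[nH]ncc12`: 17000 nM
compound 2 `N#Cc1cc(NCc2ccccc2[N+](=O)[O-])c2cn[nH]c2c1`: > 100000 nM

In an assay for inhibition of Tryptophan 2,3-dioxygenase (Homo sapiens), with stated times of 10 min and 60 min (on this read-out lower numbers stand for stronger inhibition and higher numbers for weaker inhibition), compound 1 gives 17000 nM. For compound 2 the assay reports only a limit, > 100000 nM. Among the measured compounds shown here, the one measured step, an at least 5.8-fold higher number from compound 1 to compound 2 (0.76 log units; beyond the scatter), introduced the cyano group and ended at the limit of > 100000 nM in this assay, at which 1 of the 2 values shown sits. Compound 3 `COC(=O)c1cc(NCc2ccccc2[N+](=O)[O-])c2cn[nH]c2c1` carries the change (methoxycarbonyl in place of cyano on an aromatic carbon). For the measured compounds named here, no measured step covers an exchange of cyano for methoxycarbonyl; the only step in hand, an at least 5.8-fold higher number from compound 1 to compound 2 (0.76 log units; beyond the scatter), shows a substituent on this aromatic carbon weakening inhibition. Compound 2 stands at the limit, so the starting point of the new step is itself uncertain. Compound 3 is expected to remain weak, with the step of a number no higher from compound 2 to compound 3 (the limit leaves the size open) expected to stay within the scatter. The estimate for compound 3 in this assay is 100000 nM, with a range from 30000 nM to 300000 nM, and a report of only a limit is likely.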

Compound 3, half-maximal inhibitory concentration: > 100000 nM
Compound 3: a limit, no number; the forecaster's own chance of this, stated with the estimate: 70%; the middle value lies on the limit itself.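

In this assay, methoxycarbonyl in place of hydrogen on this aromatic carbon gives an at least 5.8-fold higher number from compound 1 to compound 3 (0.76 log units; beyond the scatter), so among the compounds shown the weakening at this position is not confined to cyano. For compound 3, > 100000 nM is a limit of the assay and not a number. Cyano and methoxycarbonyl cannot be ordered, and the step between compound 2 and compound 3 cannot be read, as each compound has only a limit: the limit of > 100000 nM in this assay, at which 2 of the 3 values shown sit.

From the compounds shown here alone, how far compound 2 and compound 3 lie past that limit stays open. Also open, going by these compounds, is whether a substituent on this carbon can keep inhibition at all, for example an amine, a carboxylic acid or a methyl group.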